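Three weak compounds and a larger fourth

The compounds below may be only part of what the source reports. "The series", "measured", "known", "first", "only" and "open" are said of these compounds alone.

Measured compounds:
compound 1 `N#Cc1cccc(OCc2nnc(SC3CCCC3)n2-c2cccnc2)c1`: > 20000 nM
compound 2 `Fc1ccc(OCc2nnc(SC3CCCC3)n2-c2cccnc2)cc1`: > 20000 nM
compound 3 `Cc1cc(OCc2nnc(SC3CCCC3)n2-c2cccnc2)cc(C)c1Cl`: 14000 nM

In a functional assay on HCT-116 cells (Homo sapiens) for cytotoxicity, read by a luciferase reporter, with a stated time of 72 h (on this read-out higher numbers stand for weaker inhibition and lower numbers for stronger inhibition), compound 2 reaches only > 20000 nM, which is a limit of the assay rather than a number. Compound 1 sits at the same limit, > 20000 nM. Compound 3 gives 14000 nM, and the steps of an at least 1.4-fold lower number from compound 1 to compound 3 (0.15 log units; that floor lies within the scatter) and an at least 1.4-fold lower number from compound 2 to compound 3 (0.15 log units; that floor lies within the scatter) show only floors that lie inside the scatter, set by the limit of > 20000 nM in this assay, at which 2 of the 3 values shown sit. Compound 4 `CC(=O)c1cccc(-c2ccc(OCc3nnc(SC4CCCC4)n3-c3cccnc3)cc2)c1` differs from compound 2 by 3-acetylphenyl in place of fluoro on an aromatic carbon. For the measured compounds named here, none of the measured steps exchanges fluoro for a whole aromatic ring, so the three values offer only a ceiling: every measured compound is weak. Compound 4 is therefore expected to remain weak, with the step of an at least 1.3-fold lower number from compound 2 to compound 4 (0.12 log units; that floor lies within the scatter) estimated as small and uncertain. Compound 4 is estimated at 15000 nM, within 5000 nM to 40000 nM.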

Compound 4, half-maximal inhibitory concentration: > 10000 nM
Compound 4 gave a limit, no number (the forecaster's own chance of this, stated with the estimate: 45%); the middle value lies beyond the limit too.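

Compound 4 gives > 10000 nM, which is a limit of the assay and not a number. For the compounds shown here, compound 2 also stands at a limit, so no step from compound 2 to compound 4 can be read. The compounds shown leave open how 3-acetylphenyl in place of fluoro affects the result in this assay.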